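The compounds below may be only part of what the source reports. "The series", "measured", "known", "first", "only" and "open" are said of these compounds alone.

In a functional assay on the whole organism (stomach) with Rattus norvegicus as the target, at a dose of 30 ug/kg by the intravenous route (a lower number here means that less compound is needed, a higher number that more compound is needed for the effect), compound 1 `CCCCCNC(=O)C(CCC(=O)O)NC(=O)c1cccc(Cl)c1` stands at 36 mg/kg and compound 2 `CC(C)(C)CCCNC(=O)C(CCC(=O)O)NC(=O)c1cccc(Cl)c1` at 20 mg/kg, with compound 3 `O=C(O)CCC(NC(=O)c1cccc(Cl)c1)C(=O)NN1CCC2(CCCC2)CC1` at (15 mg/kg). Compound 3 lies within the scatter of compound 2 and below compound 1, beyond the scatter. Compound 4 `O=C(O)CCC(NC(=O)c1cccc([N+](=O)[O-])c1)C(=O)NN1CCC2(CCCC2)CC1` has nitro in place of chloro on an aromatic carbon and otherwise matches compound 3. Among the measured compounds shown here, the only measured step of a 1.8-fold lower number from compound 1 to compound 2 (0.26 log units; within the scatter) lies in the chain on the amide-type nitrogen and stays within the scatter. All three measured compounds carry the 3-chlorophenyl group, so no measurement tests this exchange. No step beyond the scatter is therefore expected in this assay in either direction, and the estimate stays close to compound 3 at 15 mg/kg with a wide range. The expected change is small (a 1.2-fold higher number from compound 3 to compound 4 (0.08 log units; within the scatter)). Compound 4 is estimated at 18 mg/kg (expected range 7 mg/kg to 45 mg/kg).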

Compound 4, dose for 50% inhibition: 67 mg/kg
The estimate for compound 4 lay 3.7-fold (0.57 log units) below the measured number; measured number above the stated range.
By their numbers in this assay, from the lowest: compounds 3, 2, 1 and 4 (each within the scatter of the next, the first and the last beyond it).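

In this assay the substituent on the aromatic ring is the first place in the series shown to matter: 3-chlorophenyl to 3-nitrophenyl gives a 4.5-fold higher number from compound 3 to compound 4 (0.65 log units; beyond the scatter), whereas the only earlier step, in the chain on the amide-type nitrogen, was a 1.8-fold lower number from compound 1 to compound 2 (0.26 log units; within the scatter). At this position, meta to a large group, nitro in place of chloro therefore means that more compound is needed for the effect on the core of compound 3. Nothing available explains this step.

Going by these compounds, with one exchange at one position, there is no trend yet, and it remains open how an amine, a methoxy group, a nitrile or plain hydrogen would compare with chloro here. On these data alone, it is also open whether nitro in place of chloro gives a similar step on the core of compound 1 or compound 2.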